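Series notes: heteroaryl swap at the exocyclic carbon

The compounds below may be only part of what the source reports. "The series", "measured", "known", "first", "only" and "open" are said of these compounds alone.

Measured so far in a functional assay on NCI-H460 cells (Homo sapiens) for cytotoxicity, read by MTT assay, with a stated time of 72 h; a higher number here means a weaker inhibitor, a lower number a stronger inhibitor:
- compound 1 `CC(C)c1[nH]cnc1/C=c1\[nH]c(=O)/c(=C/c2cccc(Oc3ccc(F)cc3)c2)[nH]c1=O`: 8.8 nM
- compound 2 `CC(C)c1[nH]cnc1/C=c1\[nH]c(=O)/c(=C/c2cccc(C(=O)c3ccc(F)cc3)c2)[nH]c1=O`: 3.2 nM
- compound 3 `CC(C)(C)S(=O)(=O)OCc1ccc(/C=c2\[nH]c(=O)/c(=C/c3cccc(Oc4ccc(F)cc4)c3)[nH]c2=O)o1`: 378 nM

Compound 1 stands second highest of the three numbers. Its nearest neighbour is compound 2, reached by a 2.8-fold lower number from compound 1 to compound 2 (0.44 log units; beyond the scatter), a change at the other aryl group. Compound 3 `CC(C)(C)S(=O)(=O)OCc1ccc(/C=c2\[nH]c(=O)/c(=C/c3cccc(Oc4ccc(F)cc4)c3)[nH]c2=O)o1` carries a different group at the position in question here; its value sits far above that of compound 1, but the two structures differ in a way that is not a single counted change, so only the two values themselves can be compared.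

Compound 4 `O=c1[nH]/c(=C\c2nc3ccccc3[nH]2)c(=O)[nH]/c1=C\c1cccc(Oc2ccc(F)cc2)c1` is the next compound. It differs from compound 1 by 1H-benzimidazol-2-yl in place of 5-isopropyl-1H-imidazol-4-yl on a double-bonded chain carbon bound to an aromatic carbon.

Within the data shown here, no measured step touches this position. Among the measured compounds shown here, the only measured step, from compound 1 to compound 2, concerns another part of the molecule and gives no guidance on the direction here. With nothing to anchor the change, a modest step in this assay in either direction is plausible; the weaker showing of compound 3 at this same position, with its value 378 nM, cautions that alterations here can cost potency. Compound 4 is therefore expected to give about 25 nM in this assay, between 6 nM and 120 nM, meaning an expected step of a 2.8-fold higher number from compound 1 to compound 4 (0.45 log units; beyond the scatter).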

Compound 4, half-maximal inhibitory concentration: > 1000 nM
Compound 4: only a limit was reported; the forecaster's own chance of this, stated with the estimate: 2%; middle value at least 40-fold (1.60 log units) away from the limit.
By their numbers in this assay, from the lowest: compound 2; then compound 1; then compound 3. At a limit, above all of these: compound 4.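

In this assay, 1H-benzimidazol-2-yl in place of 5-isopropyl-1H-imidazol-4-yl on a double-bonded chain carbon bound to an aromatic carbon gives an at least 110-fold higher number from compound 1 to compound 4 (2.05 log units; beyond the scatter), the first single-place step read at this position. The reading for compound 4 is a limit of the assay and not a number: the limit of > 1000 nM in this assay, at which 1 of the 4 values shown sits. The hydrogen-bond donor and acceptor counts are the same in both groups, so this large loss of potency comes with no change in those counts, while the isopropyl goes and a six-membered aromatic ring of carbon only comes in.

The compounds shown do not separate the loss of the isopropyl from the gain of that ring. As far as these compounds go, how a methyl or a primary amine on the imidazole would read at this position remains open.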